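This account rests on a few compounds, and the source may have more. Where it says the series, first, only, none or still open, it means among the compounds named here.

Measured in a functional assay on MCF7 cells (Homo sapiens) for cytotoxicity, read by MTT assay, with a stated time of 72 h (on this read-out higher numbers stand for weaker inhibition and lower numbers for stronger inhibition), so far:
compound 1, `CN1[C@@H]2c3[nH]c4ccccc4c3C[C@H]1[C@H](C#N)N1[C@@H](CNC(=O)c3ccc(Cl)cc3)c3[nH]c4ccccc4c3C[C@@H]21`: 610 nM
compound 2, `COc1ccc(C(=O)NC[C@H]2c3[nH]c4ccccc4c3C[C@H]3[C@H]4c5[nH]c6ccccc6c5C[C@@H]([C@H](C#N)N23)N4C)cc1`: 600 nM
compound 3, `CN1[C@@H]2c3[nH]c4ccccc4c3C[C@H]1[C@H](C#N)N1[C@@H](CNC(=O)c3cc4ccccc4o3)c3[nH]c4ccccc4c3C[C@@H]21`: 320 nM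

Compound 2 holds the second highest of the three numbers. Its nearest neighbour is compound 1, with a 1.0-fold lower number from compound 1 to compound 2 (0.01 log units; within the scatter); its furthest is compound 3, with a 1.9-fold lower number from compound 2 to compound 3 (0.27 log units; within the scatter). The remaining pair gives a 1.9-fold lower number from compound 1 to compound 3 (0.28 log units; within the scatter). All three values sit within the scatter of one another.

Compound 4, `CN1[C@@H]2c3[nH]c4ccccc4c3C[C@H]1[C@H](C#N)N1[C@@H](CNC(=O)/C=C/c3ccccc3)c3[nH]c4ccccc4c3C[C@@H]21`, differs from compound 2 in one place: 2-phenylethenyl in place of 4-methoxyphenyl on a carbonyl carbon. The steps that exchange the group on this carbonyl carbon, from compound 1 to compound 3 and from compound 2 to compound 3, both stayed within the scatter, so no step beyond the scatter is expected here either, a 1.2-fold lower number from compound 2 to compound 4 (0.08 log units; within the scatter). For compound 4 the expected value in this assay is 500 nM, within 200 nM to 1300 nM.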

Compound 4, half-maximal inhibitory concentration: 7190 nM
Compound 4: the middle estimate sits 14-fold (1.16 log units) below what was measured; the measured number lies above the stated range.
By their numbers in this assay, from the lowest: compounds 3, 2 and 1 (each within the scatter of the next); then compound 4.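

In this assay, within the data shown here, this carbonyl carbon proves less tolerant than the earlier compounds showed: 2-phenylethenyl gives large steps beyond the scatter (a 12-fold higher number from compound 2 to compound 4 (1.08 log units; beyond the scatter); a 12-fold higher number from compound 1 to compound 4 (1.07 log units; beyond the scatter); a 22-fold higher number from compound 3 to compound 4 (1.35 log units; beyond the scatter)), while the other three groups stayed within the scatter of one another. Against 4-methoxyphenyl, the heavy-atom count is unchanged, so that count alone does not track the result. Nothing available bears on the reason for these steps.

From the compounds shown here alone, whether the double bond outside aromatic rings matters remains open. A saturated 2-phenylethyl group on this carbonyl carbon would test that directly.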